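The compounds below may be only part of what the source reports. "The series", "measured", "known", "first", "only" and "open" are said of these compounds alone.

The series shares one core, seen in compound 1 `CNC(=O)c1ccc(Sc2ccc(NC(=S)Nc3ccc(F)c(F)c3)cc2)nc1`, which in a functional assay on HCT-116 cells (Homo sapiens) for cytotoxicity, read by MTT assay, with a stated time of 48 h (on this read-out higher numbers stand for weaker inhibition and lower numbers for stronger inhibition), gives 22200 nM. Going by the values given here, compound 2 `CNC(=O)c1ccc(Sc2cccc(NC(=S)Nc3ccc(OC(F)(F)F)cc3)c2)nc1` in this assay gives 24500 nM, a number that sits within the scatter of the one for compound 1. Compound 3 `CNC(=O)c1ccc(Sc2cccc(NC(=S)Nc3cc(C(F)(F)F)cc(C(F)(F)F)c3)c2)nc1` in this assay gives 5020 nM, the lowest of the three numbers; its distance from compound 1, its nearest neighbour, and from compound 2, the furthest, both lie well beyond the scatter, so compound 3 is the strongest inhibitor of the three in this assay.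

Compound 4 `CNC(=O)c1ccc(Sc2cccc(NC(=S)Nc3cccc(C(F)(F)F)c3)c2)nc1` has not yet been measured. It differs from compound 3 in one place: hydrogen in place of trifluoromethyl on an aromatic carbon. Among the compounds with values here, no step between measured compounds matches this change, so the expectation rests on the three numbers alone. Since every compound without two trifluoromethyl groups, compound 1 and compound 2, gives a higher number than compound 3, a modest rise, beyond the scatter but short of the gap to compound 1, is the expected direction. This change is expected to produce a step of a 2.4-fold higher number from compound 3 to compound 4 (0.38 log units; beyond the scatter) in this assay. Compound 4 is therefore estimated to give 12000 nM, with a range from 4000 nM to 35000 nM.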

Compound 4, half-maximal inhibitory concentration: 16200 nM
Estimate against measurement, compound 4: 1.4-fold (0.13 log units) below, within the range that was stated.
By their numbers in this assay, from the lowest: compound 3; then compounds 4, 1 and 2 (each within the scatter of the next).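

Hydrogen in place of trifluoromethyl on an aromatic carbon gives the first reading of this position in this assay: the change brings a 3.2-fold higher number from compound 3 to compound 4 (0.51 log units; beyond the scatter), a modest step beyond the scatter. The second trifluoromethyl group therefore has a measurable part in the lower number of compound 3, even though one trifluoromethyl group stays on the same ring in compound 4. This could not be read from compound 1, compound 2 and compound 3 alone, since no two of them differed in only one place. No measurement shown here accounts for the step, so it stands as an observation without an explanation.

From the compounds shown here alone, whether the lower number depends on trifluoromethyl itself remains open, since a chlorine atom, a methoxy group, an amine or a carboxylic acid at this place could give a number close to that of compound 3 or far from it. Going by these compounds, it is also open whether the same change would give a step of similar size on a compound with the substitution pattern of the shared core seen in compound 1.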